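Dimethylamino in place of hydroxy: growth inhibition notes

This account rests on a few compounds, and the source may have more. Where it says the series, first, only, none or still open, it means among the compounds named here.

In a functional assay on A549 cells (Homo sapiens) for inhibition (a higher number here means a weaker inhibitor of growth, a lower number a stronger inhibitor of growth), compound 1 `NS(=O)(=O)c1ccc(/C=C/c2ccc(F)cc2)cc1` gives 8930 nM and compound 2 `NS(=O)(=O)c1ccc(/C=C/c2ccc(O)cc2)cc1` gives 13900 nM. Among the compounds with values here, the only measured step, a 1.6-fold higher number from compound 1 to compound 2 (0.19 log units; within the scatter), lies within the scatter, so compound 2 cannot be told apart from compound 1. Compound 3 `CN(C)c1ccc(/C=C/c2ccc(S(N)(=O)=O)cc2)cc1` carries dimethylamino in place of hydroxy on an aromatic carbon. Within the data shown here, that single step, also an exchange on an aromatic carbon, is the only guide, and it offers no basis for expecting a real shift. The expected change is a 1.4-fold lower number from compound 2 to compound 3 (0.14 log units; within the scatter), not beyond the scatter. For compound 3 the estimated value is 10000 nM, with an expected range of 3000 nM to 30000 nM.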

Compound 3, concentration for 50% growth inhibition: 10100 nM
Compound 3: the middle estimate sits 1.0-fold (0.00 log units) below what was measured; the range from low to high includes it.
By their numbers in this assay, from the lowest: compounds 1, 3 and 2 (each within the scatter of the next).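

In this assay, a third group on an aromatic carbon, para to a large group, leaves the number within the scatter in both readable steps (a 1.4-fold lower number from compound 2 to compound 3 (0.14 log units; within the scatter); a 1.1-fold higher number from compound 1 to compound 3 (0.05 log units; within the scatter)). Dimethylamino removes the hydrogen-bond donor of hydroxy and adds heavy atoms, yet neither exchange gives a separable shift, so fluoro, hydroxy and dimethylamino cannot be ranked here. No supporting measurement bears on this result. On these data alone, whether a carboxylic acid, a primary amine or a longer chain at this position would move the number beyond the scatter remains open. Changes elsewhere on the shared core are also unresolved.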